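Hydroxyls for Methoxys: One Change Across Two Cores

This account rests on a few compounds, and the source may have more. Where it says the series, first, only, none or still open, it means among the compounds named here.

Compound 1 `COc1ccc(Oc2ccc(C(C)C)cc2-c2ccsc2S(=O)(=O)NCCNC(=S)Nc2cc(C(F)(F)F)cc(C(F)(F)F)c2)cc1OC` and compound 3 `CC(C)c1ccc(Oc2ccc(O)c(O)c2)c(-c2ccsc2S(=O)(=O)NCCNC(=S)Nc2cc(C(F)(F)F)cc(C(F)(F)F)c2)c1` share one core and differ in a single place: 3,4-dihydroxyphenyl in place of 3,4-dimethoxyphenyl on an oxygen on an aromatic ring. In an ADME assay on HEK-293T cells (Homo sapiens) for cytotoxicity, read by CCK-8 assay, with a stated time of 48 h (on this read-out lower numbers stand for stronger inhibition and higher numbers for weaker inhibition), compound 1 gives 10200 nM. In this assay compound 3 gives 18100 nM. The change made a step of a 1.8-fold higher number from compound 1 to compound 3 (0.25 log units; within the scatter), so the two compounds cannot be told apart on this read-out.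

Compound 2 `COc1ccc(Oc2ccccc2-c2ccsc2S(=O)(=O)N2CCN(C(=S)Nc3ccc(Cl)cc3)CC2)cc1OC` rests on a different core; how its core differs from that of compound 1 is not broken down here. In this assay compound 2 reaches only a limit of the assay, > 20000 nM, which is the limit of > 20000 nM in this assay, at which 1 of the 3 values shown sits.

Compound 4 `O=S(=O)(c1sccc1-c1ccccc1Oc1ccc(O)c(O)c1)N1CCN(C(=S)Nc2ccc(Cl)cc2)CC1` has not yet been measured in this assay. It carries the same change relative to compound 2: 3,4-dihydroxyphenyl in place of 3,4-dimethoxyphenyl on an oxygen on an aromatic ring. Because the measured step of a 1.8-fold higher number from compound 1 to compound 3 (0.25 log units; within the scatter) stayed within the scatter, the step from compound 2 to compound 4 is expected to be small as well, a step that the limit leaves unreadable from compound 2 to compound 4. Compound 4 is therefore estimated at 25000 nM in this assay, with a likely range from 12000 nM to 60000 nM. A limit rather than a number is also a likely outcome.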

Compound 4, half-maximal inhibitory concentration: > 50000 nM
Compound 4 gave a limit, no number; the forecaster's own chance of this, stated with the estimate: 70%; at least 2.0-fold (0.30 log units) between middle value and limit.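

In this assay, for the compounds shown here, compound 2 gives only a limit of the assay, > 20000 nM, so no step to compound 4 can be read. Compound 4 also gives only a limit, > 50000 nM. The compounds shown leave open what 3,4-dihydroxyphenyl in place of 3,4-dimethoxyphenyl does on the core of compound 2.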